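This account rests on a few compounds, and the source may have more. Where it says the series, first, only, none or still open, it means among the compounds named here.

Values so far in a functional assay on HeLa cells (Homo sapiens) for antiproliferative activity, read by MTT assay, with a stated time of 48 h; a lower number here means a stronger inhibitor, a higher number a weaker inhibitor:
- compound 1 `C=C(/C=C/c1ccc(OC)c(O)c1)c1cc(OC)c(OC)c(OC)c1`: 320 nM
- compound 2 `CC=C(/C=C/c1ccc(OC)c(N)c1)c1cc(OC)c(OC)c(OC)c1`: 217 nM
- compound 3 `C=C(/C(C)=C/c1ccc(OC)c(O)c1)c1cc(OC)c(OC)c(OC)c1`: 60 nM

Compound 3 holds the lowest number of the three, and its gaps to compound 2 and compound 1 both lie beyond the scatter. Compound 4 `CCCC=C(/C(C)=C/c1ccc(OC)c(O)c1)c1cc(OC)c(OC)c(OC)c1` differs from compound 3 by one change: propyl in place of hydrogen on a double-bonded chain carbon bound to a double-bonded chain carbon. Going by the values given here, no measured pair isolates this change, so the expectation is weakly grounded. A step towards a higher number in this assay is expected, probably beyond the scatter, since compound 3 at 60 nM is the lowest value in the series. The estimated change is a 4.2-fold higher number from compound 3 to compound 4 (0.62 log units; beyond the scatter). Compound 4 is estimated at 250 nM, with an expected range of 60 nM to 1500 nM.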

Compound 4, half-maximal inhibitory concentration: 3130 nM
For compound 4 the middle estimate is 13-fold (1.10 log units) below the measured one; measured number above the stated range.
By their numbers in this assay, from the lowest: compound 3; then compounds 2 and 1 (each within the scatter of the next); then compound 4.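

In this assay, going by these compounds alone, propyl in place of hydrogen on a double-bonded chain carbon bound to a double-bonded chain carbon gives a 52-fold higher number from compound 3 to compound 4 (1.72 log units; beyond the scatter), the first single-place step. On the background of compound 3, this position therefore does not accept propyl without a large move towards weaker inhibition. Nothing available explains this step.

A single substituent cannot show whether a methyl or an ethyl at this carbon would stay near compound 3 or whether the loss builds with chain length. Going by these compounds, how an amine or a hydroxymethyl group would behave here also remains open.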